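Swapping 2,3-dimethoxyphenyl for 2,4-difluorophenyl on a shared core

The source may report more compounds than this note shows. Statements on the series, on what has been measured and on what is new or still open speak of the compounds shown alone.

Three compounds have been measured in a functional assay on MCF7 cells (Homo sapiens) for cytotoxicity, read by MTT assay, with a stated time of 72 h (a higher number here means a weaker inhibitor, a lower number a stronger inhibitor), so far:
- compound 1 (`O=C1C(=Cc2ccc(O)cc2)C(=O)N(c2ccc(Cl)cc2)N1c1ccc(Cl)cc1`) gives 23200 nM in this assay
- compound 2 (`COc1ccc(C=C2C(=O)N(c3ccc(Cl)cc3)N(c3ccc(Cl)cc3)C2=O)cc1`) gives > 128000 nM as a limit
- compound 3 (`COc1cccc(C=C2C(=O)N(c3ccc(Cl)cc3)N(c3ccc(Cl)cc3)C2=O)c1OC`) gives 11900 nM in this assay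

Compound 3 shares the low end of these values with one other compound. That gap is a 1.9-fold lower number from compound 1 to compound 3 (0.29 log units; within the scatter) and sets no order between the two. The value for compound 2 is a limit and not a number.

Compound 4 (`O=C1C(=Cc2ccc(F)cc2F)C(=O)N(c2ccc(Cl)cc2)N1c1ccc(Cl)cc1`) differs from compound 3 in one place, on a double-bonded chain carbon bound to a double-bonded ring carbon, where 2,4-difluorophenyl takes the place of 2,3-dimethoxyphenyl (2,4-difluorophenyl in place of 2,3-dimethoxyphenyl on a double-bonded chain carbon bound to a double-bonded ring carbon).

Changes in this same group have had very uneven results. The step of an at least 10-fold lower number from compound 2 to compound 3 (1.03 log units; beyond the scatter) is large, and the step of an at least 5.5-fold higher number from compound 1 to compound 2 (0.74 log units; beyond the scatter) is at least modest, while the gap above stays within the scatter. Going by the values given here, none of the measured compounds carries fluorine, so these steps fix the size of the next one only loosely. A modest rise is expected in this assay and is estimated as a 2.5-fold higher number from compound 3 to compound 4 (0.40 log units; beyond the scatter) for this change. The estimate for compound 4 is 30000 nM (expected range 8000 nM to 110000 nM).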

Compound 4, half-maximal inhibitory concentration: 22000 nM
Estimate against measurement, compound 4: 1.4-fold (0.13 log units) above; the measured number falls inside the stated range.
By their numbers in this assay, from the lowest: compounds 3, 4 and 1 (each within the scatter of the next). At a limit, above all of these: compound 2.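

Placing 2,4-difluorophenyl on the double-bonded chain carbon bound to a double-bonded ring carbon gives a result in this assay that stays close to both active compounds, a 1.8-fold higher number from compound 3 to compound 4 (0.27 log units; within the scatter) and a 1.1-fold lower number from compound 1 to compound 4 (0.02 log units; within the scatter), so compounds 1, 3 and 4 cannot be put in order. This shows that, among the compounds shown, neither an oxygen on the aromatic ring nor a hydrogen-bond acceptor in this group is needed to reach this range of values, since 2,4-difluorophenyl has neither, yet the change still separates from the 4-methoxyphenyl of compound 2, an at least 5.8-fold lower number from compound 2 to compound 4 (0.76 log units; beyond the scatter). Compound 2 thus remains the only one apart from the others, and its value is a limit and not a number: the limit of > 128000 nM in this assay, at which 1 of the 4 values shown sits.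

The compounds shown do not settle whether the two fluorines act together or whether one alone would give the same value, and a plain phenyl group would help to show what the substituents contribute at all. Nor do they show how this position responds to a group of another kind, such as an amine or a carboxylic acid on the aromatic ring.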